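A few compounds are considered here, and "the series" means these few. Any claim that something is new, unique, unknown or untested is made for them only; others in the source may bear on it.

Measured in a functional assay on SW1573 cells (Homo sapiens) for inhibition, read by sulforhodamine B assay, with a stated time of 48 h; on this read-out higher numbers stand for weaker inhibition of growth and lower numbers for stronger inhibition of growth:
- compound 1 `O=C(CCC(F)(F)C(F)(F)C(F)(F)C(F)(F)F)NCCCCCCCCCN[C@@H]1[C@H](O)[C@@H](O)[C@H](O)[C@H]2COC(=O)N21`: > 100000 nM (a limit of the assay, not a number)
- compound 2 `O=C(CCC(F)(F)C(F)(F)C(F)(F)C(F)(F)C(F)(F)C(F)(F)F)NCCCCCCCCCN[C@@H]1[C@H](O)[C@@H](O)[C@H](O)[C@H]2COC(=O)N21`: 14000 nM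

Within the data shown here, compound 2 holds the only exact number so far, 14000 nM. Compound 3 `O=C(CCC(F)(F)C(F)(F)C(F)(F)C(F)(F)C(F)(F)C(F)(F)C(F)(F)C(F)(F)F)NCCCCCCCCCN[C@@H]1[C@H](O)[C@@H](O)[C@H](O)[C@H]2COC(=O)N21` differs from it by 1,1,2,2,2-pentafluoroethyl in place of fluoro on a saturated chain carbon bound to two fluorine atoms and a saturated chain carbon. Among the measured compounds shown here, only one measured step bears on this change: an at least 7.1-fold lower number from compound 1 to compound 2 (0.85 log units; beyond the scatter), which is the same replacement. That step starts from a limit. A further move towards stronger growth inhibition is therefore expected, with a size estimated as a 2.8-fold lower number from compound 2 to compound 3 (0.45 log units; beyond the scatter). For compound 3 the estimated value is 5000 nM, with an expected range of 1500 nM to 18000 nM.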

Compound 3, concentration for 50% growth inhibition: > 100000 nM
Compound 3 gave a limit, no number; the forecaster's own chance of this, stated with the estimate: 7%; middle value at least 20-fold (1.30 log units) away from the limit.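

In this assay, the same replacement of fluoro by 1,1,2,2,2-pentafluoroethyl does not act in one direction at this position: one step gives an at least 7.1-fold lower number from compound 1 to compound 2 (0.85 log units; beyond the scatter), the next an at least 7.1-fold higher number from compound 2 to compound 3 (0.85 log units; beyond the scatter). Further extension of the fluorinated chain therefore does not continue the gain seen at compound 2. Compound 1 and compound 3 cannot be ranked against each other, as both rest on a limit of the assay, not a number: the limit of > 100000 nM in this assay, at which 2 of the 3 values shown sit.

Going by these compounds, whether a plain alkyl chain in place of the fluorinated chain would give a number in this assay stays open. So does whether the growth inhibition depends on fluorine at all.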